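The compounds below may be only part of what the source reports. "The series", "measured", "known", "first", "only" and "open" are said of these compounds alone.

Working notes on the series. Compound 1 `COc1ccc(C(C)C)cc1CN[C@H]1[C@H](C(C)(C)C)[C@@H](C(=O)O)N(C(=O)C2CCCCC2)[C@H]1c1ccccc1` and compound 2 `COc1ccc(C(C)(C)C)cc1CN[C@H]1[C@H](C(C)(C)C)[C@@H](C(=O)O)N(C(=O)C2CCCCC2)[C@H]1c1ccccc1` share the core and differ at one saturated chain carbon. In an assay on HBE cells for positive allosteric modulation of Cystic fibrosis transmembrane conductance regulator variant F508del (Homo sapiens) (on this read-out higher numbers stand for larger maximal responses and lower numbers for smaller maximal responses), compound 1 gives 191%. Compound 2 gives 195% on this assay, which is a number 4 percentage points higher from compound 1 to compound 2 (within the scatter), so compound 2 and compound 1 sit at one level. Compound 3 `COc1ccc(C23CC4CC42C3)cc1CN[C@H]1[C@H](C(C)(C)C)[C@@H](C(=O)O)N(C(=O)C2CCCCC2)[C@H]1c1ccccc1` brings in a group of 6 heavy atoms (6 carbon; 2 three-membered non-aromatic rings of carbon only, one four-membered non-aromatic ring of carbon only) in place of a group of 4 heavy atoms (4 carbon; no ring), on an aromatic carbon. Among the measured compounds shown here, the only step that bears on it is a number 4 percentage points higher from compound 1 to compound 2 (within the scatter), a change at the same aromatic carbon that stayed within the scatter; no measured step covers a ring-bearing group here. The expected step of a number 5 percentage points lower from compound 2 to compound 3 (within the scatter) is therefore none beyond the scatter. Compound 3 is estimated at 190%, range 160% to 215%.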

Compound 3, largest response reached (reported as percent of maximum), in percent of the reference or control that the assay uses: 173%
The estimate for compound 3 lay 17 percentage points above the measured number, within the range that was stated.
By their numbers in this assay, from the lowest: compound 3; then compounds 1 and 2 (each within the scatter of the next).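

At the aromatic carbon para to a methoxy group, the read-out in this assay does respond to the group placed there: the ring-bearing group brings a number 22 percentage points lower from compound 2 to compound 3 (beyond the scatter) and a number 18 percentage points lower from compound 1 to compound 3 (beyond the scatter). Both steps are modest, and the earlier change from isopropyl to tert-butyl at this carbon stayed within the scatter. Nothing available accounts for the drop.

As far as these compounds go, whether the drop follows the fused rings or the larger group remains open. A single cyclopropyl ring or a cyclohexyl ring at this carbon would bear on that.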